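A few compounds are considered here, and "the series" means these few. Any claim that something is new, unique, unknown or untested is made for them only; others in the source may bear on it.

In an ADME assay on a cell-free system (plasma, Rattus norvegicus) for protein binding, compound 2 `O=C(Nc1ccc(Cl)c(C(F)(F)F)c1)N[C@H]1CCN(c2ccncn2)C1` gives 99.4%, the highest unbound fraction among the two compounds measured, while compound 1 `O=C(Nc1ccc(Cl)c(C(F)(F)F)c1)N[C@H]1CCN(c2ccnc(NC3CC3)n2)C1` gives 99.9%. Compound 3 `CCNc1nccc(N2CC[C@H](NC(=O)Nc3ccc(Cl)c(C(F)(F)F)c3)C2)n1` differs from compound 2 by ethylamino in place of hydrogen on an aromatic carbon. Among the measured compounds shown here, one measured step bears on this change: a 6.0-fold higher unbound fraction from compound 1 to compound 2 (0.78 log units; beyond the scatter), where a cyclopropylamino group left that aromatic carbon. Putting an ethylamino group there is expected to undo much of that gain, a modest drop in unbound fraction, a 3.0-fold lower unbound fraction from compound 2 to compound 3 (0.48 log units; beyond the scatter). Compound 3 is therefore estimated at 99.8%, with a likely range from 99.5% to 99.95%.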

Compound 3, plasma protein binding: 99.9%
Compound 3: the middle estimate sits 2.0-fold (0.30 log units) (unbound fraction) above what was measured, within the range that was stated.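

Ethylamino on this aromatic carbon is enough for the whole drop, with a 6.0-fold lower unbound fraction from compound 2 to compound 3 (0.78 log units; beyond the scatter), as large as the gain seen when cyclopropylamino left that carbon. Swapping the group on the nitrogen matters little here, with no change at the digits printed from compound 1 to compound 3 (within the scatter), so the cyclopropyl ring is not needed for the low unbound fraction in these compounds. Nothing available explains why either group has this effect. Still open, going by these compounds, is whether a plain amine, a methoxy group, a carboxylic acid or a longer chain on this carbon would lower the unbound fraction just as far.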